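Piperidine ring methylation in a fluorophenyl-urea series

This account rests on a few compounds, and the source may have more. Where it says the series, first, only, none or still open, it means among the compounds named here.

Compound 1 `COc1ccc(/C=N/NC(=O)Nc2ccc(Oc3ccnc4cc(OCCCN5CCCCC5)c(OC)cc34)c(F)c2)cc1` gives 540 nM in a functional assay on A549 cells (Homo sapiens) for cytotoxicity, read by MTT assay, with a stated time of 72 h; on this read-out lower numbers stand for stronger inhibition and higher numbers for weaker inhibition. Compound 2 `COc1cc2c(Oc3ccc(NC(=O)N/N=C/c4cccs4)cc3F)ccnc2cc1OCCCN1CCCCC1` gives 790 nM in this assay, and a 1.5-fold higher number from compound 1 to compound 2 (0.17 log units; within the scatter) leaves the two compounds within the scatter of each other, so compound 1 stands apart from nothing measured. Compound 3 `COc1ccc(/C=N/NC(=O)Nc2ccc(Oc3ccnc4cc(OCCCN5CCC(C)CC5)c(OC)cc34)c(F)c2)cc1` differs from compound 1 by methyl in place of hydrogen on a saturated ring carbon. Among the measured compounds shown here, the only measured step concerns the group on a carbon with a double bond to nitrogen, a different part of the molecule, so no measured step bears on this change. For compound 3 no step beyond the scatter is expected, a 1.1-fold higher number from compound 1 to compound 3 (0.05 log units; within the scatter), with an estimated 600 nM and a range of 250 nM to 1500 nM.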

Compound 3, half-maximal inhibitory concentration: 430 nM
Estimate against measurement, compound 3: 1.4-fold (0.14 log units) above, and the stated range covers the measured number.
By their numbers in this assay, from the lowest: compounds 3, 1 and 2 (each within the scatter of the next).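

In this assay, among the compounds shown here, methyl in place of hydrogen on the saturated ring carbon three ring bonds from the ring nitrogen gives a 1.3-fold lower number from compound 1 to compound 3 (0.10 log units; within the scatter) and is the only measured change on the piperidine ring. For the compounds shown here, on the 4-methoxyphenyl compounds, piperidin-1-yl to 4-methylpiperidin-1-yl therefore brings no step that can be told from the scatter. Nothing measured here speaks to the reason for this result. As far as these compounds go, how a hydroxyl, a carboxylic acid or a phenyl on this ring carbon would read remains open. So does the same methyl on the thiophen-2-yl partner, compound 2.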